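Substituent at the saturated ring carbon: thiophene to benzyl

A few compounds are considered here, and "the series" means these few. Any claim that something is new, unique, unknown or untested is made for them only; others in the source may bear on it.

Compound 1 `CN1C(=O)C(C2CC2)N(C)c2nc(Nc3ccc(S(N)(=O)=O)cc3)ncc21`: 136 nM
Compound 2 `CN1C(=O)C(c2cccs2)N(C)c2nc(Nc3ccc(S(N)(=O)=O)cc3)ncc21`: 88 nM

Among the measured compounds shown here, in an assay on Sf9 cells for inhibition of serine/threonine-protein kinase 4 (Homo sapiens), read by luminescence and ADP-Glo, with a stated time of 1 h, in the presence of a further agent that is not named here (on this read-out higher numbers stand for weaker inhibition and lower numbers for stronger inhibition), compound 2 gives 88 nM, the lower of the two numbers, though the only measured step, a 1.5-fold lower number from compound 1 to compound 2 (0.19 log units; within the scatter), lies within the scatter. Compound 3 `CN1C(=O)C(Cc2ccccc2)N(C)c2nc(Nc3ccc(S(N)(=O)=O)cc3)ncc21` differs from compound 2 by benzyl in place of thiophen-2-yl on a saturated ring carbon. For the measured compounds named here, the step from compound 1 to compound 2 is the one comparison that bears on this exchange at the same saturated ring carbon, and it stayed within the scatter. No step beyond the scatter is therefore expected, a 1.3-fold higher number from compound 2 to compound 3 (0.10 log units; within the scatter). Compound 3 is estimated at 110 nM, in a range from 40 nM to 300 nM.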

Compound 3, half-maximal inhibitory concentration: > 10000 nM
Compound 3: only a limit was reported (the forecaster's own chance of this, stated with the estimate: 3%); middle value at least 90-fold (1.95 log units) from the limit.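

Benzyl brings an at least 110-fold higher number from compound 2 to compound 3 (2.05 log units; beyond the scatter) and an at least 73-fold higher number from compound 1 to compound 3 (1.86 log units; beyond the scatter) at this saturated ring carbon, so a position that barely separated cyclopropyl from thiophen-2-yl does discriminate among its substituents. Thiophen-2-yl and benzyl both carry an aromatic ring, so the presence of such a ring alone does not decide the outcome. The result for compound 3 is a limit, not a number: the limit of > 10000 nM in this assay, at which 1 of the 3 values shown sits.

Open, going by these compounds, is whether phenyl attached directly to this carbon would behave like thiophen-2-yl or like benzyl. Also open, on these data alone, is how an amine or a carboxylic acid on a short chain would fare here.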